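A few compounds are considered here, and "the series" means these few. Any claim that something is new, unique, unknown or untested is made for them only; others in the source may bear on it.

- compound 1 `COc1cc(C(=O)c2cn(-c3ccccc3)cc2-c2ccc(N)cc2)cc(OC)c1OC` gives 9 nM
- compound 2 `COc1cc(C(=O)c2cn(-c3ccc(Cl)cc3)cc2-c2ccccc2)cc(OC)c1OC` gives 140 nM
- compound 3 `COc1cc(C(=O)c2cn(-c3ccccc3)cc2-c2ccccc2Cl)cc(OC)c1OC` gives 76 nM

In a functional assay on MCF7 cells (Homo sapiens) for cytotoxicity, read by MTT assay, with a stated time of 96 h (on this read-out lower numbers stand for stronger inhibition and higher numbers for weaker inhibition), compound 3 gives 76 nM as its reading. That places it within the usual scatter of compound 2 and clearly apart from compound 1, whose number is lower beyond the scatter. Compound 4 `COc1cc(C(=O)c2cn(-c3ccccc3)cc2-c2ccccc2Br)cc(OC)c1OC` has not yet been measured. It differs from compound 3 by a single swap bromo in place of chloro on an aromatic carbon in which bromo takes the place of chloro on an aromatic carbon, ortho to a large group. For the measured compounds named here, the one measured step that reaches compound 3 is an 8.4-fold higher number from compound 1 to compound 3 (0.93 log units; beyond the scatter) and it is modest in size. Going by the values given here, that step trades 4-aminophenyl for 2-chlorophenyl, so it says little about chloro against bromo, and no measured pair makes that exchange directly. A shift beyond the scatter is therefore not expected in this assay here. The expected change is a 1.1-fold higher number from compound 3 to compound 4 (0.02 log units; within the scatter) and it stays inside the scatter. For compound 4 the estimated value is 80 nM with an expected range from 35 nM to 180 nM in this measurement.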

Compound 4, half-maximal inhibitory concentration: 190 nM
For compound 4 the middle estimate is 2.4-fold (0.38 log units) below the measured one, and the stated range ends below it.
By their numbers in this assay, from the lowest: compound 1; then compounds 3, 2 and 4 (each within the scatter of the next, the first and the last beyond it).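

In this assay, this place on the ring proves sensitive to the identity of its halogen: exchanging a single atom gives a 2.5-fold higher number from compound 3 to compound 4 (0.40 log units; beyond the scatter), so bromo here goes with weaker inhibition than chloro. The gap to the 4-aminophenyl compound also widens, with a 21-fold higher number from compound 1 to compound 4 (1.32 log units; beyond the scatter) compared with an 8.4-fold higher number from compound 1 to compound 3 (0.93 log units; beyond the scatter) for the chlorinated partner. No measurement shown here accounts for the difference between chloro and bromo.

With only these two halogens compared at this place, the compounds shown do not tell how fluoro, methyl or methoxy would read there. They also leave open whether the same exchange of chloro for bromo would matter on the other phenyl ring, where compound 2 carries its chloro.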